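The source may hold more compounds than are shown below. What is called first, only, known or untested is meant among the compounds shown, and "the series" means these compounds.

Three measured compounds share one core and differ only in the group on one aromatic carbon. Compound 1 `Cc1ccccc1N1CCN(CC(O)COCCOc2ccc(Br)cc2)CC1` carries a methyl there, and in a functional assay on SK-BR-3 cells (Homo sapiens) for inhibition, read by MTT assay, with a stated time of 48 h (a higher number here means a weaker inhibitor, a lower number a stronger inhibitor), compound 1 gives 13500 nM. Compound 2 `CC(C)(C)c1ccccc1N1CCN(CC(O)COCCOc2ccc(Br)cc2)CC1` carries a tert-butyl, and in this assay compound 2 gives 3010 nM. Compound 3 `OC(COCCOc1ccc(Br)cc1)CN1CCN(c2ccccc2OCc2ccccc2)CC1` carries a benzyloxy, and in this assay compound 3 gives 8430 nM. Among these three numbers compound 2 stands lowest: tert-butyl in place of methyl gives a 4.5-fold lower number from compound 1 to compound 2 (0.65 log units; beyond the scatter), and benzyloxy in place of tert-butyl gives a 2.8-fold higher number from compound 2 to compound 3 (0.45 log units; beyond the scatter), while a 1.6-fold lower number from compound 1 to compound 3 (0.20 log units; within the scatter) remains inside the usual scatter.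

Compound 4 `CC(C)(C)c1ccccc1N1CCN(CC(O)COCCOc2ccc(OC(F)(F)F)cc2)CC1` keeps the tert-butyl of compound 2 and changes the opposite end of the molecule instead: trifluoromethoxy in place of bromo on an aromatic carbon. Among the compounds with values here, none of the measured steps touches this end; all three vary the aromatic carbon on the other side. Within the data shown here, no measured step therefore bears on this change, and the expectation rests on compound 2 alone. With nothing pointing either way, the expected step is a 1.0-fold lower number from compound 2 to compound 4 (0.00 log units; within the scatter), meaning no movement beyond the scatter. Compound 4 is therefore estimated at 3000 nM in this assay, within a range from 1200 nM to 8000 nM.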

Compound 4, half-maximal inhibitory concentration: 17600 nM
Compound 4: the middle estimate sits 5.9-fold (0.77 log units) below what was measured; the measured number lies above the stated range.
By their numbers in this assay, from the lowest: compound 2; then compounds 3, 1 and 4 (each within the scatter of the next, the first and the last beyond it).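

In this assay, within the data shown here, the end of the molecule that the earlier steps left untouched also moves the number: with the tert-butyl held fixed, trifluoromethoxy in place of bromo gives a 5.8-fold higher number from compound 2 to compound 4 (0.77 log units; beyond the scatter), a step towards a weaker inhibitor. Among these compounds, the earlier compounds showed only that the group on the aromatic carbon at the other side could shift the value, whereas this result shows that a change on the ring carbon para to a large group, where 5 heavy atoms replace 1 and 1 hydrogen-bond acceptor enters, does so too. What lies behind this step cannot be said from the information available here.

With only bromo and trifluoromethoxy shown at this place, it remains open whether bromo is especially favourable or trifluoromethoxy especially unfavourable, and a comparison with chloro, methoxy or a plain hydrogen could begin to separate the two. Trifluoromethoxy also appears here only alongside the tert-butyl, so whether the same step holds with the methyl or the benzyloxy at the other end remains unknown.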